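Amino for hydrogen on two related cores: working notes

This account rests on a few compounds, and the source may have more. Where it says the series, first, only, none or still open, it means among the compounds named here.

Compound 1 `CCn1cc(-c2nc3ccccc3[nH]2)c(=O)c2cc(F)c(N3CCNCC3)cc21` and compound 2 `CCn1cc(-c2nc3ccccc3[nH]2)c(=O)c2cc(F)c(N3CCNCC3)nc21` share most of their structure; the difference between the two cores is not broken down here. In a functional assay on HeLa cells (Homo sapiens) for cytotoxicity, read by sulforhodamine B assay, with a stated time of 48 h (a higher number here means a weaker inhibitor, a lower number a stronger inhibitor), compound 2 gives 10000 nM, the only result in this set that is reported as a number. Compound 1 reaches only a limit of the assay in this assay, namely > 10000 nM. Compound 3 `CCn1cc(-c2nc3ccc(N)cc3[nH]2)c(=O)c2cc(F)c(N3CCNCC3)cc21` carries amino in place of hydrogen on an aromatic carbon. Compound 3 likewise stops at a limit in this assay, namely > 10000 nM. The step that the two limits leave unreadable from compound 1 to compound 3 is therefore not readable, a consequence of the limit of > 10000 nM in this assay, at which 2 of the 3 values shown sit. The set thus holds no measured size for this change.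

Compound 4 `CCn1cc(-c2nc3ccc(N)cc3[nH]2)c(=O)c2cc(F)c(N3CCNCC3)nc21` is the matching partner of compound 2 and carries amino in place of hydrogen on an aromatic carbon. The place is described in exactly the same words as for compound 3, so this is the same change made on the other core. Among the compounds with values here, because compound 2 gives 10000 nM as a number, while the one measured instance of the change yields no readable size, the expectation for compound 4 rests on compound 2 alone, with the change taken as roughly neutral. The expected step is a 1.2-fold higher number from compound 2 to compound 4 (0.08 log units; within the scatter). Compound 4 is estimated at 12000 nM in this assay, with a range from 5000 nM to 30000 nM, and there is a fair chance that the assay reports only a limit for it.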

Compound 4, half-maximal inhibitory concentration: > 10000 nM
Compound 4: a limit, no number; the forecaster's own chance of this, stated with the estimate: 60%; the middle value does not contradict the limit.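

In this assay the amino group in place of hydrogen on the core of compound 2 gives a number no lower from compound 2 to compound 4 (the limit leaves the size open). Compound 4 gives > 10000 nM, which is a limit of the assay and not a number. From the compounds shown here alone, this shows that, on the core of compound 2, the change brings no lower number in this assay; it does not show how large the step is, and neither step of this change can be read, so it remains unknown whether the change acts alike on the two cores, because the results gather at one limit: the limit of > 10000 nM in this assay, at which 3 of the 4 values shown sit.

The compounds shown carry only hydrogen or amino at this place on the aromatic carbon, so it remains open whether another group there, such as a carboxylic acid, a methoxy group or an amine on a longer chain, would give a readable number on either core. Also open, going by these compounds, is how far compound 1, compound 3 and compound 4 lie from one another, which only a reading beyond the limit of the assay could settle.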